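The compounds below may be only part of what the source reports. "The series", "measured", "known", "first", "only" and "open" are said of these compounds alone.

Working notes on the series. Compound 1 `CCn1cc(Nc2nc(N)nc(-c3cccc(-n4ccc5cc(C6CC6)cc(F)c5c4=O)c3CO)n2)cc1C#N` and compound 2 `CC(C1CC1)n1cc(Nc2nc(N)nc(-c3cccc(-n4ccc5cc(C6CC6)cc(F)c5c4=O)c3CO)n2)cn1` share one core and differ only in the group on a nitrogen on an aromatic ring. Within the data shown here, in a physicochemical assay for solubility, read by LC-MS, measured as kinetic solubility, with a stated time of 1 h (on this read-out lower numbers stand for lower solubility and higher numbers for higher solubility), compound 1 gives 710 nM, and in this assay compound 2 gives 2000 nM, so compound 2 holds the higher of the two numbers measured so far, the step being a 2.8-fold higher number from compound 1 to compound 2 (0.45 log units; beyond the scatter).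

Compound 3 `Cn1cc(Nc2nc(N)nc(-c3cccc(-n4ccc5cc(C6CC6)cc(F)c5c4=O)c3CO)n2)cc1C#N` is the next member. Its change from compound 2 is 5-cyano-1-methyl-1H-pyrrol-3-yl in place of 1-(1-cyclopropylethyl)-1H-pyrazol-4-yl on a nitrogen on an aromatic ring. Among the measured compounds shown here, this largely reverses the one measured step, since the 5-cyano-1-methyl-1H-pyrrol-3-yl group that enters differs from the 5-cyano-1-ethyl-1H-pyrrol-3-yl group of compound 1 only in the methyl in place of ethyl. For the measured compounds named here, a downward step roughly the size of the measured one is therefore expected because a 2.8-fold higher number from compound 1 to compound 2 (0.45 log units; beyond the scatter) is the only guide. In this assay a step of a 2.7-fold lower number from compound 2 to compound 3 (0.43 log units; beyond the scatter) is expected. For compound 3 the estimate in this assay is 750 nM, within a range of 350 nM to 1600 nM.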

Compound 3, solubility: 670 nM
The estimate for compound 3 lay 1.1-fold (0.05 log units) above the measured number, and the stated range covers the measured number.
By their numbers in this assay, from the lowest: compounds 3 and 1 (each within the scatter of the next); then compound 2.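

Exchanging 5-cyano-1-ethyl-1H-pyrrol-3-yl for 5-cyano-1-methyl-1H-pyrrol-3-yl at this position gives, in this assay, a 1.1-fold lower number from compound 1 to compound 3 (0.03 log units; within the scatter), so the ethyl and methyl chains on the nitrogen of this pyrrole are not told apart by this read-out. The larger exchange, 5-cyano-1-methyl-1H-pyrrol-3-yl in place of 1-(1-cyclopropylethyl)-1H-pyrazol-4-yl, gives a 3.0-fold lower number from compound 2 to compound 3 (0.47 log units; beyond the scatter), which places both cyano-bearing pyrrole groups on the same side of the gap to the pyrazole group of compound 2. No supporting data bear on why this gap arises.

The exchange changes the ring, the nitrile and the chain together, so these three compounds cannot assign the gap to any one of them. As far as these compounds go, how a 1-methyl-1H-pyrazol-4-yl group, or a chain ending in an amine or a carboxylic acid, would read at this position remains open.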